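Trading a Fused Lactam for a Smaller Ring

The source may hold more compounds than are shown below. What is called first, only, known or untested is meant among the compounds shown, and "the series" means these compounds.

Of the compounds shown here, three share a common core and have been measured in a physicochemical assay for solubility, read by LC-MS, in phosphate buffer, with a stated time of 24 h, at pH 7.4; a lower number here means a less soluble compound, a higher number a more soluble compound. Compound 1 `Cc1cc(-c2cnc(NCc3c(F)ccc4c3CCO4)c3cn[nH]c(=O)c23)n(C)n1` gives 1000 nM, compound 2 `O=C1c2ccccc2CN1c1cnc(NCc2c(F)ccc3c2CCO3)n2cnnc12` gives 4000 nM, and compound 3 `CN(C)Cc1ccc2c(c1)CN(c1cnc(NCc3c(F)ccc4c3CCO4)c3cn[nH]c(=O)c13)C2=O` gives 174000 nM. Compound 2 therefore stands second highest of the three, with compound 1 nearest and compound 3 furthest away. Compound 4 `C[C@@H]1CC(=O)N(c2cnc(NCc3c(F)ccc4c3CCO4)n3cnnc23)C1` has not yet been measured. Relative to compound 2 the change is a group of 7 heavy atoms (5 carbon, 1 nitrogen, 1 oxygen; one five-membered non-aromatic ring with 1 hetero atom) in place of a group of 10 heavy atoms (8 carbon, 1 nitrogen, 1 oxygen; one five-membered non-aromatic ring with 1 hetero atom, one six-membered aromatic ring of carbon only), on an aromatic carbon: the group that enters is smaller and carries no six-membered aromatic ring of carbon only. Among the measured compounds shown here, no comparable step has been measured here. An upward step in this assay is expected, of about a 3.8-fold higher number from compound 2 to compound 4 (0.57 log units; beyond the scatter) from compound 2 to compound 4. Compound 4 is estimated at 15000 nM, in a range from 5000 nM to 50000 nM.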

Compound 4, solubility: 130000 nM
Compound 4: the middle estimate sits 8.7-fold (0.94 log units) below what was measured; the measured number lies above the stated range.
By their numbers in this assay, from the lowest: compound 1; then compound 2; then compounds 4 and 3 (each within the scatter of the next).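

On this aromatic carbon, the group held here can move the number a long way: 4-methyl-2-oxopyrrolidin-1-yl, in place of the larger group with its six-membered aromatic ring of carbon only, goes with a 33-fold higher number from compound 2 to compound 4 (1.51 log units; beyond the scatter) in this assay. Nothing measured here gives a cause for this step.

This single step cannot separate the loss of the aromatic ring from the gain of the methyl group and its defined stereocentre. Where a carboxylic acid on this same carbon would fall also remains open.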